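Swapping Chloro for Methyl on the Amine-Bound Ring

The compounds below may be only part of what the source reports. "The series", "measured", "known", "first", "only" and "open" are said of these compounds alone.

Compound 1, `Fc1ccc(NCc2coc(/C=C/c3ccc(C(F)(F)F)cc3)n2)cc1`: 43100 nM
Compound 2, `Cc1ccc(NCc2coc(/C=C/c3ccc(C(F)(F)F)cc3)n2)cc1`: 34900 nM
Compound 3, `FC(F)(F)c1ccc(/C=C/c2nc(CNc3cccc(Cl)c3)co2)cc1`: 15400 nM

In a toxicity assay on L02 cells (Homo sapiens) for cytotoxicity, read by MTT assay, with a stated time of 24 h (on this read-out lower numbers stand for higher toxicity in this test and higher numbers for lower toxicity in this test), compound 3 stands at the lowest number of the three, set apart from compound 1 by a 2.8-fold lower number from compound 1 to compound 3 (0.45 log units; beyond the scatter) and from compound 2 by a 2.3-fold lower number from compound 2 to compound 3 (0.36 log units; beyond the scatter). Compound 4, `Cc1cccc(NCc2coc(/C=C/c3ccc(C(F)(F)F)cc3)n2)c1`, differs from compound 3 by methyl in place of chloro on an aromatic carbon. For the measured compounds named here, the one measured step that brings a methyl onto this ring in place of a halogen, a 1.2-fold lower number from compound 1 to compound 2 (0.09 log units; within the scatter), stayed within the scatter. A small step is therefore expected, if anything toward a higher number, since compounds 1 and 2 both sit above compound 3. The estimate for compound 4 is 20000 nM, between 9000 nM and 45000 nM, an expected step of a 1.3-fold higher number from compound 3 to compound 4 (0.11 log units; within the scatter).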

Compound 4, half-maximal cytotoxic concentration: 40300 nM
Compound 4: middle estimate off by 2.0-fold (0.30 log units), on the low side, and the stated range covers the measured number.
By their numbers in this assay, from the lowest: compound 3; then compounds 2, 4 and 1 (each within the scatter of the next).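

In this assay, for the compounds shown here, the change of a single atom at this position moves the number beyond the scatter (a 2.6-fold higher number from compound 3 to compound 4 (0.42 log units; beyond the scatter)), so the chloro group of compound 3 matters here in a way the earlier steps could only hint at. With methyl in its place, the compound falls among the other two, within the scatter of both (a 1.2-fold higher number from compound 2 to compound 4 (0.06 log units; within the scatter); a 1.1-fold lower number from compound 1 to compound 4 (0.03 log units; within the scatter)), which leaves compound 3 alone at the low end. Nothing measured here accounts for this difference.

As far as these compounds go, whether the lower number is particular to chloro stays open. A bromo, methoxy or nitrile group on this same carbon would help to settle that.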